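From 4-chlorobenzyl to 4-methoxybenzyl: a small expected step

The compounds below may be only part of what the source reports. "The series", "measured", "known", "first", "only" and "open" are said of these compounds alone.

In a physicochemical assay for acid dissociation, compound 1 `CN(Cc1ccc(N(C)C)cc1)Cc1cccc(CNc2ccnc3cc(Cl)ccc23)c1` gives 7.36 and compound 2 `CN(Cc1ccc(Cl)cc1)Cc1cccc(CNc2ccnc3cc(Cl)ccc23)c1` gives 7.55 so far, two numbers within the scatter of each other. Compound 3 `COc1ccc(CN(C)Cc2cccc(CNc3ccnc4cc(Cl)ccc34)c2)cc1` has methoxy in place of chloro on an aromatic carbon in the same place. For the measured compounds named here, the one measured step there is a number 0.19 log units higher from compound 1 to compound 2 (within the scatter) for chloro in place of dimethylamino on an aromatic carbon, so nothing beyond the scatter is expected in this assay here. The expected change is a number 0.10 log units lower from compound 2 to compound 3 (within the scatter) and no more. For compound 3 the estimated value is 7.45 within an expected range from 7.2 to 7.7 in this measurement.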

Compound 3, acid dissociation constant: 7.38
Compound 3: the middle estimate sits 0.07 log units above what was measured; the range from low to high includes it.
By their numbers in this assay, from the lowest: compounds 1, 3 and 2 (each within the scatter of the next).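

In this assay, methoxy on this aromatic carbon gives a number 0.17 log units lower from compound 2 to compound 3 (within the scatter) and, set against dimethylamino, a number 0.02 log units higher from compound 1 to compound 3 (within the scatter) as well. Chloro, methoxy and dimethylamino, para to a large group, thus all stand within the scatter of one another, so this position has so far shown no difference in this read-out. No evidence is at hand that bears on this result. As far as these compounds go, whether a carboxylic acid or a primary amine in this place would stay within the scatter remains open, as does the effect of a longer chain.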